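Cyano to ethyl on the aryl sulfonamide

The compounds below may be only part of what the source reports. "The series", "measured", "known", "first", "only" and "open" are said of these compounds alone.

Measured so far:
compound 1 `CC(C)CN(c1ccc(C#N)cc1)S(=O)(=O)c1ccc2c(c1)C(=O)CC(C1CCOCC1)O2` — 3.16
compound 2 `CCc1ccc(N(CC(C)C)S(=O)(=O)c2ccc3c(c2)C(=O)CC(C2CCN(C(=O)C4CCCC4)CC2)O3)cc1` — 5.13

In a physicochemical assay for lipophilicity, at pH 7.4 (a lower number here means a more polar compound, a higher number a more lipophilic compound), compound 1 gives 3.16 and stands lowest of the two measured values. Among the measured compounds shown here, the nearest is compound 2 with 5.13, a gap beyond the scatter, though the two structures differ in more than one place, so no single step is read from them.

Compound 3 `CCc1ccc(N(CC(C)C)S(=O)(=O)c2ccc3c(c2)C(=O)CC(C2CCOCC2)O3)cc1` is not yet measured. It differs from compound 1 in one place: ethyl in place of cyano on an aromatic carbon. For the measured compounds named here, no measured pair isolates this change, so the direction rests on the groups themselves. Ethyl in place of cyano on an aromatic carbon is expected to raise the distribution coefficient, and the expected step from compound 1 to compound 3 is a number 1.34 log units higher from compound 1 to compound 3 (beyond the scatter), clearly beyond the scatter. Compound 3 is estimated at 4.5, with a range of 3.9 to 5.1.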

Compound 3, distribution coefficient: 4.21
Beside the measured number, compound 3's estimate is 0.29 log units above it; measured number inside the range.
By their numbers in this assay, from the lowest: compound 1; then compound 3; then compound 2.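

With 4-cyanophenyl changed to 4-ethylphenyl, the series has its first change in one place, and this assay reads a number 1.05 log units higher from compound 1 to compound 3 (beyond the scatter). This aromatic position, para to a large group, therefore responds clearly in this read-out, even though both groups carry 2 heavy atoms and neither brings a ring, a donor or a net charge; the counted difference is the nitrile's 1 hydrogen-bond acceptor and triple bond. No supporting measurement bears on why the number moves, so the step stands as an observation on this single pair.

Open, as far as these compounds go, is how other groups at this position would read, such as an amine, a carboxylic acid or a longer chain. Also open, from the compounds shown here alone, is whether a step of this size would recur on the rest of the structure of compound 2.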